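A few compounds are considered here, and "the series" means these few. Any claim that something is new, unique, unknown or untested is made for them only; others in the source may bear on it.

In a functional assay on Dorsal root ganglion for antagonist activity at transient receptor potential cation channel subfamily V member 1 (Rattus norvegicus) (on this read-out lower numbers stand for stronger inhibition and higher numbers for weaker inhibition), three compounds of the series have been run. Compound 1 `CC(C)(C)c1ccc(NC(=O)N2CCN(c3ccccn3)CC2)cc1` gives 150 nM, the lowest number of the three. Compound 2 `CC(C)(C)c1ccc(NC(=O)c2ccc(-c3ccccc3)cc2)cc1` gives 3600 nM. Compound 3 `CC(C)(C)c1ccc(NC(=O)c2ccc(-c3cccnc3)cc2)cc1` gives 1300 nM, which stands second highest of the three numbers, with compound 2 nearest and compound 1 furthest away. Among the compounds with values here, the one single-place step within the amide pair, a 2.8-fold lower number from compound 2 to compound 3 (0.44 log units; beyond the scatter), is modest but beyond the scatter.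

Compound 4 `CC(C)(C)c1ccc(NC(=O)c2ccc(-c3ncccn3)cc2)cc1` is not yet measured. The change from compound 3: pyrimidin-2-yl in place of pyridin-3-yl on an aromatic carbon. Within the data shown here, only the step from compound 2 to compound 3 bears on this, as it too swaps the ring on that aromatic carbon, and it gave a modest lowering of the number. Whether a second hetero atom in the entering ring continues in that direction is not shown by any measured pair, so the expectation is a step in this assay of at most modest size, more likely downward than upward, and possibly none beyond the scatter.

Compound 4 is therefore expected to give about 1000 nM in this assay, within 350 nM to 3500 nM. That estimate corresponds to a step of a 1.3-fold lower number from compound 3 to compound 4 (0.11 log units; within the scatter).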

Compound 4, half-maximal inhibitory concentration: 60 nM
Estimate against measurement, compound 4: 17-fold (1.22 log units) above, outside the stated range (below it).
By their numbers in this assay, from the lowest: compound 4; then compound 1; then compound 3; then compound 2.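

In this assay, the ring on this aromatic carbon, para to a large group, can carry far more than a 2.8-fold lower number from compound 2 to compound 3 (0.44 log units; beyond the scatter) had indicated: pyrimidin-2-yl gives a 22-fold lower number from compound 3 to compound 4 (1.34 log units; beyond the scatter), and measured against phenyl it gives a 60-fold lower number from compound 2 to compound 4 (1.78 log units; beyond the scatter). A hetero atom in this ring is thus not enough for a large step, as pyridin-3-yl gives only the modest one, and the size of the step depends strongly on which nitrogen-containing ring occupies the position. Pyridin-3-yl and pyrimidin-2-yl differ both in the count of hetero atoms and in the ring positions of those atoms, the two compounds do not separate these differences, and nothing measured here accounts for the large step.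

Pyrimidin-5-yl or pyrazin-2-yl on the same carbon would show whether the second nitrogen alone goes with the lower number or whether its ring position also matters. Also open, going by these compounds, is whether an amine or a methoxy group on the pyrimidin-2-yl ring keeps the number this low, and whether the result holds beyond this assay and this one core.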